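A few compounds are considered here, and "the series" means these few. Any claim that something is new, unique, unknown or untested is made for them only; others in the source may bear on it.

In an ADME assay on isolated protein for inhibition of Amine oxidase [flavin-containing] A (Homo sapiens), read by fluorescence and Amplex Red, with stated times of 15 min and 20 min (a higher number here means a weaker inhibitor, a lower number a stronger inhibitor), the two measured compounds read as follows:
compound 1, `C#CCN(CCCCOc1ccc2ccc(=O)oc2c1)Cc1cccc(OC)c1`, gives 78600 nM
compound 2, `C#CCN(CCCOc1ccc2ccc(=O)oc2c1)Cc1ccc(C)cc1`, gives 116000 nM

Compound 1 holds the lower of the two numbers, but compound 2 sits within the usual scatter of it, so the two stand together as weak inhibitors. Compound 3, `C#CCN(CCCCOc1ccc2ccc(=O)oc2c1)Cc1ccc(F)c(F)c1`, differs from compound 1 by 3,4-difluorophenyl in place of 3-methoxyphenyl on a saturated chain carbon bound to an amine nitrogen. For the measured compounds named here, no measured pair shows this kind of change, so there is no step to lean on. The change is expected to shift the number little beyond the scatter, with a 1.1-fold lower number from compound 1 to compound 3 (0.05 log units; within the scatter). Compound 3 is therefore expected to give 70000 nM, in the range 25000 nM to 200000 nM.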

Compound 3, half-maximal inhibitory concentration: 93200 nM
Estimate against measurement, compound 3: 1.3-fold (0.12 log units) below, within the range that was stated.
By their numbers in this assay, from the lowest: compounds 1, 3 and 2 (each within the scatter of the next).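

In this assay, 3,4-difluorophenyl in place of 3-methoxyphenyl on a saturated chain carbon bound to an amine nitrogen gives a 1.2-fold higher number from compound 1 to compound 3 (0.07 log units; within the scatter) and so stays within the scatter. For the compounds shown here, this is the first step that can be read at this position, and the loss of the one hydrogen-bond acceptor counted in the leaving group comes with no change beyond the scatter. Nothing measured here gives a reason for this result.

Still open, as far as these compounds go, is whether a phenyl carrying a carboxylic acid or an amine at this position, or a longer chain, would move the number beyond the scatter.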